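This account rests on a few compounds, and the source may have more. Where it says the series, first, only, none or still open, it means among the compounds named here.

Series notes. In a physicochemical assay for lipophilicity (on this read-out lower numbers stand for lower lipophilicity and higher numbers for higher lipophilicity), compound 1 `COc1ccc2nc(-c3ccc(N(C)C)nc3)oc2c1` gives 3.7, compound 2 `CN(C)c1ccc(-c2nc3ccc(O)cc3o2)cn1` gives 1.9, and compound 3 `CNc1ccc(-c2cc3ccc(O)cc3o2)cn1` gives 2. Compound 3 and compound 2 sit within the scatter of each other in this assay; compound 1 lies clearly beyond both. Compound 2 and compound 1 differ in one place, (methyl in place of hydrogen on an oxygen on an aromatic ring), and that change produced a step of a number 1.80 log units higher from compound 2 to compound 1 (beyond the scatter). The cores of compound 2 and compound 3 differ in a way that is not broken down here. Compound 4 `CNc1ccc(-c2cc3ccc(OC)cc3o2)cn1` has not yet been measured in this assay; it differs from compound 3 by methyl in place of hydrogen on an oxygen on an aromatic ring, the same change as between compound 2 and compound 1, at the same kind of place on the core of compound 3. Because the step of a number 1.80 log units higher from compound 2 to compound 1 (beyond the scatter) was large and the change is the same, compound 4 is expected to lie well above compound 3, though the core differs, so the step is estimated a little smaller at a number 1.50 log units higher from compound 3 to compound 4 (beyond the scatter). For compound 4 the expected value in this assay is 3.5, with a range of 2.8 to 4.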

Compound 4, distribution coefficient: 3.8
Estimate against measurement, compound 4: 0.30 log units below; the range from low to high includes it.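

In this assay the change from hydroxy to methoxy gives a number 1.80 log units higher from compound 3 to compound 4 (beyond the scatter) and, on the other core, a number 1.80 log units higher from compound 2 to compound 1 (beyond the scatter) as well, so the two steps are of the same size and the change carried over intact between these two cores. This rests on just two matched pairs: it does not establish a rule for other cores, for other places on the core, or for any other read-out, and the cores of compound 2 and compound 3 differ in a way that is not broken down here. Nothing at hand explains the size of the step or its constancy across the two cores.

Only hydrogen and methyl appear on this oxygen in the compounds shown, which leaves open whether ethyl, a longer chain or a chain ending in an amine would continue the step in this assay or depart from it. Also open, as far as these compounds go, is whether a carboxylic acid elsewhere on these cores would alter the size of the step.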